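The source may hold more compounds than are shown below. What is called first, only, known or untested is meant among the compounds shown, and "the series" means these compounds.

Measured so far in a functional assay on A2780 cells (Homo sapiens) for cytotoxicity, read by MTT assay; a lower number here means a stronger inhibitor, a higher number a weaker inhibitor:

- compound 1, `CC(C)[C@@H](O)C(=O)c1c[nH]c2ccccc12`: > 10000 nM, a limit of the assay rather than a number
- compound 2, `CC(C)(O)C(=O)Cc1cn([C@@H]2O[C@H](CO)[C@@H](O)[C@H](O)[C@H]2O)c2ccccc12`: > 10000 nM, again a limit
- compound 3, `CC(C)(O)[C@@H](O)C[C@]1(O)C(=O)N([C@@H]2O[C@H](CO)[C@@H](O)[C@H](O)[C@H]2O)c2ccccc21`: > 10000 nM, again a limit

Compound 2 therefore stands nowhere in particular on a scale of potency: its value in this assay is a limit, and the same holds across the whole set, as summarised by the limit of > 10000 nM in this assay, at which 3 of the 3 values shown sit. Going by the values given here, no pair of measured compounds differs in a single place, so no measured step is available to lean on.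

The unmeasured compound is compound 4, `CC(C)(O)[C@@H](O)Cc1cn([C@@H]2O[C@H](CO)[C@@H](O)[C@H](O)[C@H]2O)c2ccccc12`. Against compound 2 the change is 1,2-dihydroxy-2-methylpropyl in place of (1-hydroxy-1-methylethyl)carbonyl on a saturated chain carbon bound to an aromatic carbon. What leaves is (1-hydroxy-1-methylethyl)carbonyl, what enters is 1,2-dihydroxy-2-methylpropyl, on a saturated chain carbon bound to an aromatic carbon; cut one bond further out it reads ((1-hydroxy-1-methylethyl)carbonyl)methyl to 2,3-dihydroxy-3-methylbutyl.

With every shown value at the limit and no measured step, the expected step from compound 2 to compound 4 in this assay is none beyond the scatter: a step that the limit leaves unreadable from compound 2 to compound 4. Compound 4 is accordingly expected to sit at 15000 nM, within 6000 nM to 40000 nM, most likely reported again only as a limit.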

Compound 4, half-maximal inhibitory concentration: > 10000 nM
Compound 4: only a limit was reported (the forecaster's own chance of this, stated with the estimate: 85%); the middle value is on the limit's open side.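

In this assay, compound 2 and compound 4 are both reported only as limits, so no step can be read for 1,2-dihydroxy-2-methylpropyl in place of (1-hydroxy-1-methylethyl)carbonyl. The compounds shown leave open whether any change to this series gives a readable value, and which change would do so: the limit of > 10000 nM in this assay, at which 4 of the 4 values shown sit.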